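From Compound 1 to Compound 4 at the Growth Limit

The compounds below may be only part of what the source reports. "The series", "measured", "known", "first", "only" and "open" are said of these compounds alone.

Compound 1 (`C=CC(=O)NCc1ccc(C(=O)Nc2ccc(C)c(Nc3nccc(-c4cccnc4)n3)c2)cc1`) was tested in an ADME assay on BaF3 cells (Mus musculus) for cytotoxicity, read by CellTiter-Glo and CCK-8 assay, with a stated time of 72 h; on this read-out lower numbers stand for stronger inhibition of growth and higher numbers for weaker inhibition of growth. Compound 1 gives > 10000 nM, which is a limit of the assay and not a number. Its trifluoromethyl analogue, compound 3 (`C=CC(=O)NCc1ccc(C(=O)Nc2ccc(C)c(Nc3nccc(-c4cccnc4)n3)c2)cc1C(F)(F)F`), gives > 10000 nM, again a limit. The series thus shows (the limit of > 10000 nM in this assay, at which 2 of the 3 values shown sit). Among the compounds with values here, the only measured step that starts from compound 1 is a step that the two limits leave unreadable from compound 1 to compound 3, so it supplies no size to carry forward.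

Within the data shown here, compound 2 (`CCC(=O)NCc1cccc(C(=O)Nc2ccc(C)c(Nc3nccc(-c4cccnc4)n3)c2)c1`) differs from compound 1 in more than one place and is the only compound with a readable number, with compound 2 giving 4750 nM in this assay.

Compound 4 (`C=CC(=O)Nc1ccc(C(=O)Nc2ccc(C)c(Nc3nccc(-c4cccnc4)n3)c2)cc1`) has not yet been measured. Its change from compound 1 is as follows: (vinylcarbonyl)amino in place of ((vinylcarbonyl)amino)methyl on an aromatic carbon. The (vinylcarbonyl)amino thus takes the place of ((vinylcarbonyl)amino)methyl, para to a large group. Among the measured compounds shown here, no measured step covers this exchange, so the expectation rests only on where its relatives stand. Growth inhibition is expected to remain weak, and the assay may well report only a limit again. What is expected is an at least 1.1-fold lower number from compound 1 to compound 4 (0.04 log units; that floor lies within the scatter), with its direction left open by the data. Compound 4 is estimated at 9000 nM, with an expected range from 3000 nM to 20000 nM.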

Compound 4, concentration for 50% growth inhibition: 5600 nM
The estimate for compound 4 lay 1.6-fold (0.21 log units) above the measured number; measured number inside the range.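

In this assay, the position para to a large group responds to a change in this side chain: with (vinylcarbonyl)amino in place of ((vinylcarbonyl)amino)methyl on the aromatic carbon, the data give an at least 1.7-fold lower number from compound 1 to compound 4 (0.25 log units; that floor lies within the scatter). This is a floor and not a full size, and it cannot yet separate the two compounds beyond the usual scatter, because compound 1 sits at a limit of the assay: the limit of > 10000 nM in this assay, at which 2 of the 4 values shown sit. Within the data shown here, the trifluoromethyl exchange from compound 1 to compound 3 cannot be read, as both of its values are limits, so the present exchange is the only change in one place from compound 1 that yields a readable number at all.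

The compounds shown leave open how far compound 4 truly lies from compound 1, and whether the number responds to the length of the link in a consistent way. A longer chain carrying the same (vinylcarbonyl)amino group at this position, or a plain amine there, would be needed to test whether the number moves further or returns to the limit.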